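The source may hold more compounds than are shown below. What is called first, only, known or untested is meant among the compounds shown, and "the series" means these compounds.

Series notes. Compound 1 `Cc1nc(S(C)(=O)=O)ccc1Oc1ncnc(OC2CCN(C(=O)SC(C)C)CC2)c1F` gives 6.8 nM in a functional assay on isolated protein for inhibition of Glucose-dependent insulinotropic receptor (Homo sapiens), read by HTRF and cAMP accumulation; a lower number here means that less compound is needed, a higher number that more compound is needed for the effect. Compound 2 `Cc1nc(S(C)(=O)=O)ccc1Oc1ncnc(OC2CCN(C(=S)OC(C)C)CC2)c1F` gives 69.9 nM in this assay, and compound 3 `Cc1nc(S(C)(=O)=O)ccc1Oc1ncnc(OC2CCN(C(=O)c3noc(C(C)(C)F)n3)CC2)c1F` gives 14 nM in this assay. Compound 3 thus holds the second highest of the three numbers; its nearest neighbour is compound 1, with a 2.1-fold higher number from compound 1 to compound 3 (0.31 log units; beyond the scatter), and its furthest is compound 2, with a 5.0-fold lower number from compound 2 to compound 3 (0.70 log units; beyond the scatter).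

Compound 4 `Cc1nc(S(C)(=O)=O)ccc1Oc1ncnc(OC2CCN(C(=O)c3ncc(Cl)cn3)CC2)c1F` differs from compound 3 by a group of 7 heavy atoms (4 carbon, 2 nitrogen, 1 chlorine; one six-membered aromatic ring with 2 hetero atoms) in place of a group of 9 heavy atoms (5 carbon, 2 nitrogen, 1 oxygen, 1 fluorine; one five-membered aromatic ring with 3 hetero atoms), on a carbonyl carbon whose other neighbours are an amide-type nitrogen in a ring.

Going by the values given here, no measured step exchanges one aromatic ring on this carbonyl carbon for another. The closest comparison is a 2.1-fold higher number from compound 1 to compound 3 (0.31 log units; beyond the scatter), a modest shift when the group on the carbonyl carbon was exchanged; a 10-fold higher number from compound 1 to compound 2 (1.01 log units; beyond the scatter) and a 5.0-fold lower number from compound 2 to compound 3 (0.70 log units; beyond the scatter) concern the amine nitrogen in the ring and bear only loosely. A modest step in this assay, without a firm direction, is therefore expected. Compound 4 is expected near 15 nM, range 5 nM to 45 nM. That estimate means a step of a 1.1-fold higher number from compound 3 to compound 4 (0.03 log units; within the scatter).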

Compound 4, half-maximal effective concentration: 6.12 nM
Compound 4: the middle estimate sits 2.5-fold (0.39 log units) above what was measured; low and high end bracket the measured number.
By their numbers in this assay, from the lowest: compounds 4 and 1 (each within the scatter of the next); then compound 3; then compound 2.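

On the carbonyl carbon, one aromatic ring can now be read directly against another: in this assay, 5-chloropyrimidin-2-yl in place of the five-membered aromatic ring of compound 3 gives a 2.3-fold lower number from compound 3 to compound 4 (0.36 log units; beyond the scatter), so the choice of ring at this position does register, though modestly. The same group cannot be told apart from the open-chain isopropylsulfanyl, with a 1.1-fold lower number from compound 1 to compound 4 (0.05 log units; within the scatter), so a ring on this carbon is compatible with the lowest numbers in the series, although the five-membered ring of compound 3 goes against any general reading of rings and chains as equal here, and the step from the thiocarbamate-like compound 2, an 11-fold lower number from compound 2 to compound 4 (1.06 log units; beyond the scatter), leaves that compound with the highest number of the four. No measurement available here bears on why these groups differ or match at this position.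

The compounds shown do not separate the contribution of the chlorine from that of the pyrimidine ring, so a pyrimidin-2-yl carrying hydrogen, methyl or a nitrile in place of the chlorine would be informative. Going by these compounds, it also remains open whether a phenyl or pyridinyl ring on the same carbonyl carbon would hold the number of compound 4.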